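This account rests on a few compounds, and the source may have more. Where it says the series, first, only, none or still open, it means among the compounds named here.

Measured so far in a toxicity assay on J774.A1 cells (Mus musculus) for cytotoxicity, read by SYBR Green assay, with a stated time of 1 h; on this read-out lower numbers stand for an effect already at smaller amounts and higher numbers for an effect only at larger amounts of compound:
- compound 1 `CN(C)c1ccc2cc(-c3cn(C)c4ccccc34)c(N)nc2c1` gives 3700 nM
- compound 2 `CNc1ccc2cc(-c3cn(C)c4ccccc34)c(N)nc2c1` gives 4100 nM
- compound 3 `Cn1cc(-c2cc3ccc(N4CCCC4)cc3nc2N)c2ccccc21` gives 440 nM

Compound 3 has the lowest number of the three, and its steps to both others lie beyond the scatter. Compound 4 `Cn1cc(-c2cc3ccc(N4CCCCC4)cc3nc2N)c2ccccc21` has not yet been measured. piperidin-1-yl in place of pyrrolidin-1-yl on an aromatic carbon is the change from compound 3, with piperidin-1-yl in place of pyrrolidin-1-yl on an aromatic carbon.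

Within the data shown here, no measured step swaps one such ring for another, so the evidence is only indirect. The closest steps are an 8.4-fold lower number from compound 1 to compound 3 (0.92 log units; beyond the scatter) and a 9.3-fold lower number from compound 2 to compound 3 (0.97 log units; beyond the scatter), which replace dimethylamino and methylamino with pyrrolidin-1-yl. By contrast, a 1.1-fold higher number from compound 1 to compound 2 (0.04 log units; within the scatter) stays within the scatter. Compound 4 still carries a ring at this place, so it is expected to stay closer to compound 3 than to compound 1 or compound 2. The expected step in this assay is small, and the estimate is a 1.4-fold higher number from compound 3 to compound 4 (0.13 log units; within the scatter) and no clear shift. For compound 4 the estimated value is 600 nM with an expected range from 200 nM to 1800 nM.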

Compound 4, half-maximal effective concentration: 560 nM
Beside the measured number, compound 4's estimate is 1.1-fold (0.03 log units) above it; low and high end bracket the measured number.
By their numbers in this assay, from the lowest: compounds 3 and 4 (each within the scatter of the next); then compounds 1 and 2 (each within the scatter of the next).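

In this assay, among these compounds, this is the first swap of one ring for another at this place on the aromatic carbon, and the step (  a 1.3-fold higher number from compound 3 to compound 4 (0.10 log units; within the scatter)) lies within the scatter, so the five-membered and six-membered rings are not told apart here. The piperidin-1-yl compound also stays clearly apart from both open amino compounds (a 7.3-fold lower number from compound 2 to compound 4 (0.86 log units; beyond the scatter); a 6.6-fold lower number from compound 1 to compound 4 (0.82 log units; beyond the scatter)), which shows that the low number of compound 3 is not tied to pyrrolidin-1-yl alone. Nothing available explains why these two rings differ from the open amino groups.

Still open, as far as these compounds go, is whether closing a ring or simply having more carbon at this place goes with the lower numbers, which an open diethylamino group could help separate. Also open, from the compounds shown here alone, is where a morpholine ring, which carries an oxygen, would fall.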